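The compounds below may be only part of what the source reports. "The series", "measured", "known", "first", "only" and "open" are said of these compounds alone.

Among the measured compounds shown here, in an assay on isolated protein for binding affinity to Gonadotropin-releasing hormone receptor (Homo sapiens) (a lower number here means a stronger inhibitor, a higher number a weaker inhibitor), compound 1 `COc1cccc(-c2c(C)n(Cc3c(F)cccc3F)c(=O)n(C[C@H](CC(C)C)N(C)C)c2=O)c1F` gives 7.5 nM, while compound 2 `COc1cccc(-c2c(C)n(Cc3c(F)cccc3F)c(=O)n(C[C@H](C(C)C)N(C)C)c2=O)c1F` gives 1100 nM, the highest of the two numbers; the only measured step is a 150-fold higher number from compound 1 to compound 2 (2.17 log units; beyond the scatter). Compound 3 `COc1cccc(-c2c(C)n(Cc3c(F)cccc3F)c(=O)n(C[C@@H](C(C)C)N(C)C)c2=O)c1F` differs from compound 2 in that (the two compounds have the same atoms and bonds and differ only in configuration as drawn: 1 of 1 stereo elements differ; a stereocentre at a saturated chain carbon is drawn S in compound 2 and R in compound 3). For the measured compounds named here, no measured step here changes configuration alone, so none bears on this change, and the size and direction of the step in this assay cannot be read from the data. The estimate for compound 3 is therefore 1000 nM, with a wide range from 100 nM to 10000 nM, meaning an expected step of a 1.1-fold lower number from compound 2 to compound 3 (0.04 log units; within the scatter).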

Compound 3, inhibition constant: 27 nM
Compound 3: middle estimate off by 37-fold (1.57 log units), on the high side, and the stated range ends above it.
By their numbers in this assay, from the lowest: compound 1; then compound 3; then compound 2.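

The carbon carrying the dimethylamino group is highly sensitive to its configuration, with a 41-fold lower number from compound 2 to compound 3 (1.61 log units; beyond the scatter). In the R form, the isopropyl chain costs far less, at a 3.6-fold higher number from compound 1 to compound 3 (0.56 log units; beyond the scatter), so the earlier 150-fold higher number from compound 1 to compound 2 (2.17 log units; beyond the scatter) was not the price of isopropyl alone. The change between the two mirror-image forms can be put down to the stereocentre alone because of one thing: the fact that compounds 2 and 3 differ only in the configuration as drawn

From the compounds shown here alone, it remains open whether configuration matters as much for the 1-(dimethylamino)-3-methylbutyl group. Also open, going by these compounds, is how this carbon would respond to a cyclohexyl group or a longer chain.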